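Bromophenyl in Place of Methoxyphenyl on a Shared Core

A few compounds are considered here, and "the series" means these few. Any claim that something is new, unique, unknown or untested is made for them only; others in the source may bear on it.

Compound 1, `O=C1/C(=C\c2ccc(O)cc2)c2ccccc2N1c1c(Cl)cccc1Cl`: 33 ug/mL in a functional assay on B16-F10 cells (Homo sapiens) for cytotoxicity against B16-F10 (Mus musculus), read by MTT assay, with a stated time of 72 h; a lower number here means that less compound is needed, a higher number that more compound is needed for the effect.
Compound 2, `COc1ccc(/C=C2\C(=O)N(c3c(Cl)cccc3Cl)c3ccccc32)cc1`: > 100 ug/mL in this assay, a limit of the assay.

Compound 2 stands only at the limit of this assay, so no number is given for it, as the limit of > 100 ug/mL in this assay, at which 1 of the 2 values shown sits, records. Compound 1 gives 33 ug/mL. Within the data shown here, the one measured step, an at least 3.0-fold higher number from compound 1 to compound 2 (0.48 log units; beyond the scatter), shows the methyl on the oxygen pushing the number up beyond the scatter. Compound 3, `O=C1/C(=C\c2cccc(Br)c2)c2ccccc2N1c1c(Cl)cccc1Cl`, differs from compound 2 by 3-bromophenyl in place of 4-methoxyphenyl on a double-bonded chain carbon bound to a double-bonded ring carbon. Among the measured compounds shown here, no measured step covers this change; the step from compound 1 to compound 2 concerns only the 4-methoxyphenyl that leaves here and says nothing about 3-bromophenyl entering. The expectation therefore rests on little and is wide. Compound 3 is expected to land near the region of compound 2, the expected step being an at least 1.4-fold lower number from compound 2 to compound 3 (0.15 log units; that floor lies within the scatter). Compound 3 is estimated at 70 ug/mL, within 25 ug/mL to 200 ug/mL.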

Compound 3, concentration for half-maximal effect: 8 ug/mL
Compound 3: middle estimate off by 8.8-fold (0.94 log units), on the high side, and the stated range ends above it.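

Putting 3-bromophenyl in place of 4-methoxyphenyl, on a double-bonded chain carbon bound to a double-bonded ring carbon, gives an at least 12-fold lower number from compound 2 to compound 3 (1.09 log units; beyond the scatter) in this assay. Against the 4-hydroxyphenyl group at the same place, the change gives a 4.1-fold lower number from compound 1 to compound 3 (0.62 log units; beyond the scatter), so this position can carry a group that lowers the number well beneath both earlier compounds, whereas the earlier step showed only a rise. The first of these steps gives only a floor for the change because compound 2 stands at a limit of the assay: the limit of > 100 ug/mL in this assay, at which 1 of the 3 values shown sits.

The bromine and its place on the ring change together here, and the compounds shown do not separate the two. Going by these compounds, how an amine or a carboxylic acid in place of the bromine would read in this assay also stays open.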